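Series notes: azidomethyl replacing carboxy on the shared core

The compounds below may be only part of what the source reports. "The series", "measured", "known", "first", "only" and "open" are said of these compounds alone.

Compound 1 `CC(=O)N(C)c1cccc2c1nc(-c1c(F)cccc1F)n2Cc1c(F)cccc1F` reaches only the limit of a toxicity assay on CCRF-CEM cells (Homo sapiens) for cytotoxicity (a higher number here means that more compound is tolerated, a lower number that less compound is tolerated), giving > 100 uM, as recorded in the limit of > 100 uM in this assay, at which 1 of the 2 values shown sits. For the measured compounds named here, compound 2 `O=C(O)c1cccc2c1nc(-c1c(F)cccc1F)n2Cc1c(F)cccc1F` gives 23.5 uM in this assay, the only number in the set. Going by the values given here, the change an at least 4.2-fold lower number from compound 1 to compound 2 (0.62 log units; beyond the scatter) is the single measured step and it bears directly on what follows, as it installed the carboxy that compound 3 now loses. Compound 3 `[N-]=[N+]=NCc1cccc2c1nc(-c1c(F)cccc1F)n2Cc1c(F)cccc1F` carries the change (azidomethyl in place of carboxy on an aromatic carbon). Among the compounds with values here, no measured step removes a carboxy or introduces an azidomethyl, so the direction rests only on compound 2 having the lower number of the pair in this assay. Compound 3 is expected to move back toward more tolerated concentrations, with the step of a 1.9-fold higher number from compound 2 to compound 3 (0.28 log units; within the scatter) estimated. Compound 3 is estimated at 45 uM in this assay, within 15 uM to 140 uM.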

Compound 3, half-maximal toxic concentration: > 100 uM
Compound 3: a limit, no number; the forecaster's own chance of this, stated with the estimate: 30%; middle value at least 2.2-fold (0.34 log units) away from the limit.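

Azidomethyl in place of carboxy on this aromatic carbon gives an at least 4.2-fold higher number from compound 2 to compound 3 (0.62 log units; beyond the scatter), so in this assay compound 2 now has the lower number against two different groups at this position, not just one. Compound 3 stands at a limit of the assay, not a number, as does compound 1: the limit of > 100 uM in this assay, at which 2 of the 3 values shown sit.

The step between compound 1 and compound 3 cannot be read, so the two groups cannot be ranked against each other.

The compounds shown leave open whether the lower number belongs to the carboxy specifically or would also appear with other groups at this position, such as a methyl ester, a primary amide or an aminomethyl. They also leave open how the core behaves with a hydrogen at this position.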